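The source may hold more compounds than are shown below. What is called first, only, known or untested is meant among the compounds shown, and "the series" means these compounds.

Of the compounds shown here, two have been measured in a functional assay on JeKo-1 cells (Homo sapiens) for inhibition, read by luminescence and CellTiter-Glo, with a stated time of 72 h; on this read-out higher numbers stand for weaker inhibition and lower numbers for stronger inhibition. For the measured compounds named here, compound 2 `CCOC(=O)c1cc(-c2ccc(Oc3ccccc3)cc2)nn1Cc1cccc(NC(=O)CCl)c1` gives 400 nM in this assay, the only full number among the two values. Compound 1 `C=CC(=O)Nc1ccc(Cn2nc(-c3ccc(Oc4ccccc4)cc3)cc2C(=O)O)cc1` gives > 60000 nM in this assay, which is a limit of the assay rather than a number (the limit of > 60000 nM in this assay, at which 1 of the 2 values shown sits).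

Compound 3 `C=CC(=O)Nc1ccc(Cn2nc(-c3ccc(Oc4ccccc4)cc3)cc2C(=O)OCC)cc1` has not yet been measured. It differs from compound 2 in one place: 4-((vinylcarbonyl)amino)phenyl in place of 3-(((chloromethyl)carbonyl)amino)phenyl on a saturated chain carbon bound to an aromatic nitrogen. Compound 3 also carries the same ethyl ester as compound 2, whereas compound 1, which shares the new phenyl group, carries the free acid.

Going by the values given here, no measured pair shows this step, so the expected size is a guess. Compound 3 is expected to be weaker than compound 2, with a step from compound 2 to compound 3 of about a 7.5-fold higher number from compound 2 to compound 3 (0.88 log units; beyond the scatter) in this assay, beyond the usual scatter. For compound 3 the estimate in this assay is 3000 nM, with a range from 500 nM to 20000 nM.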

Compound 3, half-maximal inhibitory concentration: 10900 nM
Compound 3: middle estimate off by 3.6-fold (0.56 log units), on the low side, within the range that was stated.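

At the saturated chain carbon bound to an aromatic nitrogen, with the ethyl ester kept the same, replacing 3-(((chloromethyl)carbonyl)amino)phenyl with 4-((vinylcarbonyl)amino)phenyl gives a 27-fold higher number from compound 2 to compound 3 (1.44 log units; beyond the scatter) in this assay, so this position responds strongly to this change. Compound 1 stands at a limit of the assay rather than at a number: the limit of > 60000 nM in this assay, at which 1 of the 3 values shown sits 

With the 4-((vinylcarbonyl)amino)phenyl group kept the same, ethyl in place of hydrogen on an oxygen next to a carbonyl group gives an at least 5.5-fold lower number from compound 1 to compound 3 (0.74 log units; beyond the scatter), so the ester brings a measurable value where the free acid reaches the limit.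

The step from 3-(((chloromethyl)carbonyl)amino)phenyl changes two features of the group at once, and these compounds cannot show which one matters; a 3-((vinylcarbonyl)amino)phenyl group on the same core would separate them. On these data alone, how a methyl ester or a primary amide would compare with the ethyl ester also stays open.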